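Compound 4: amino in place of a sulfonyl group

The source may report more compounds than this note shows. Statements on the series, on what has been measured and on what is new or still open speak of the compounds shown alone.

Of the compounds shown here, three have been measured so far. In a physicochemical assay for solubility, read by HPLC, using the shake flask method, measured as kinetic solubility, with a stated time of 20 h, at pH 6.5, tested at 200 uM (a lower number here means a less soluble compound, a higher number a more soluble compound), compound 1 (`CS(=O)(=O)Nc1ccc2nccc(-c3ccncc3)c2n1`) gives 90000 nM. Compound 2 (`O=S(=O)(c1cccc(-c2ccc3nccc(-c4ccncc4)c3n2)c1)N1CCC(O)CC1`) gives 10000 nM, and compound 3 (`O=S(=O)(c1cccc(-c2ccc3nccc(-c4ccncc4)c3n2)c1)N1CC[C@H](O)C1`) gives 20000 nM. Compound 3 therefore sits level with compound 2, within the scatter of repeated measurements, while the gap up to compound 1 lies beyond that scatter.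

The next structure is compound 4 (`Nc1cccc(-c2ccc3nccc(-c4ccncc4)c3n2)c1`). It differs from compound 3 in one place, with amino in place of (3-hydroxypyrrolidin-1-yl)sulfonyl on an aromatic carbon.

For the measured compounds named here, only one measured step bears on this change, and only loosely. It is a 2.0-fold higher number from compound 2 to compound 3 (0.30 log units; within the scatter), which lies within the scatter and exchanges 4-hydroxypiperidin-1-yl for 3-hydroxypyrrolidin-1-yl on a sulfonyl sulfur. Going by the values given here, that step keeps the sulfonyl group, whereas the new change removes it, and no measured pair shows such a removal. The data therefore give no firm reason to expect a large move in either direction. The step expected in this assay is a 1.3-fold lower number from compound 3 to compound 4 (0.12 log units; within the scatter), which would not go beyond the scatter, although this expectation is uncertain. For compound 4 the estimated solubility is 15000 nM, with an expected range from 4000 nM to 60000 nM.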

Compound 4, solubility: < 5000 nM
Compound 4: only a limit was reported (the forecaster's own chance of this, stated with the estimate: 5%); middle value at least 3.0-fold (0.47 log units) away from the limit.
By their numbers in this assay, from the lowest: compounds 2 and 3 (each within the scatter of the next); then compound 1. At a limit, below all of these: compound 4.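

In this assay compound 4 gives < 5000 nM, which is a limit of the assay and not a number. Amino in place of (3-hydroxypyrrolidin-1-yl)sulfonyl on an aromatic carbon gives an at least 4.0-fold lower number from compound 3 to compound 4 (0.60 log units; beyond the scatter), whereas exchanging the ring on the sulfonyl sulfur gave only a 2.0-fold higher number from compound 2 to compound 3 (0.30 log units; within the scatter), so replacing the whole sulfonyl group at this position moves the reading in a way the ring exchange did not. Amino in place of (4-hydroxypiperidin-1-yl)sulfonyl gives an at least 2.0-fold lower number from compound 2 to compound 4 (0.30 log units; that floor lies within the scatter), so this pair alone cannot confirm a real drop, while 3-aminophenyl in place of methanesulfonamido on an aromatic carbon gives an at least 18-fold lower number from compound 1 to compound 4 (1.25 log units; beyond the scatter).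

As far as these compounds go, the limit leaves the full size of these steps unread, so how far compound 4 truly lies from the other three stays open. Also open, from the compounds shown here alone, is whether the drop follows from losing the sulfonyl group or from having amino there, and how a methoxy group or a carboxylic acid on this same aromatic carbon would read against amino.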